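The source may hold more compounds than are shown below. What is called first, only, known or untested is meant among the compounds shown, and "the series" means these compounds.

Series notes. Compound 1 `COc1ccc(-c2nc3cc(C(C)O)ccc3[nH]2)c(OC)c1` and compound 2 `COc1ccc(-c2nc3cc(C(C)O)ccc3[nH]2)c(OC)c1OC` share one core; compound 3 `COc1ccc(-c2nc3cc(C(C)=O)ccc3n2C2CCCCC2)cc1` and compound 4 `COc1ccc(-c2nc3cc(C(C)=O)ccc3n2C2CCCCC2)c(OC)c1` share another, and the difference between the two cores is not broken down here. In an ADME assay on MT4 cells (Homo sapiens) for cytotoxicity, read by MTT assay, with a stated time of 96 h (a higher number here means that more compound is tolerated, a lower number that less compound is tolerated), compound 1 gives >= 100000 nM, which is a limit of the assay and not a number. Compound 2 gives 79000 nM in this assay. The step of an at least 1.2-fold lower number from compound 1 to compound 2 (0.10 log units; that floor lies within the scatter) is methoxy in place of hydrogen on an aromatic carbon, and its floor rests on (the limit of >= 100000 nM in this assay, at which 1 of the 3 values shown sits). Compound 3 gives 27000 nM in this assay, the lowest of the two numbers, with compound 2 the nearest measured value. Compound 4 is not yet measured in this assay. Its change from compound 3, (methoxy in place of hydrogen on an aromatic carbon), is the same kind of change as that from compound 1 to compound 2, but the place differs: in compound 2 the new methoxy sits ortho to two methoxy groups and meta to a large group, whereas in compound 4 it sits ortho to a large group and meta to a methoxy group. Going by the values given here, the only measured instance of this change, an at least 1.2-fold lower number from compound 1 to compound 2 (0.10 log units; that floor lies within the scatter), is small. For compound 4 a step of a 1.2-fold lower number from compound 3 to compound 4 (0.09 log units; within the scatter) of similarly modest size is expected, resting on compound 3 at 27000 nM and on that earlier step. Compound 4 is therefore estimated at 22000 nM, with an expected range from 10000 nM to 50000 nM.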

Compound 4, half-maximal cytotoxic concentration: 21000 nM
Estimate against measurement, compound 4: 1.0-fold (0.02 log units) above; the measured number falls inside the stated range.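

In this assay, methoxy in place of hydrogen on an aromatic carbon of the core of compound 3 gives a 1.3-fold lower number from compound 3 to compound 4 (0.11 log units; within the scatter), so no step beyond the scatter can be read on this core. Set beside the same change on the core of compound 1, this step gives no ground for claiming that the change behaves differently on the two cores: the same change on two cores in this assay, an at least 1.2-fold lower number (0.10 log units; that floor lies within the scatter) from compound 1 to compound 2 and a 1.3-fold lower number (0.11 log units; within the scatter) from compound 3 to compound 4; the limit leaves it open whether they differ

This does not establish that the change carries over with the same size, as the series offers only two such pairs, the new methoxy does not stand in the same place in both, and the step on the core of compound 1 starts from a limit of the assay and not a number: the limit of >= 100000 nM in this assay, at which 1 of the 4 values shown sits.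

Still open, from the compounds shown here alone, is whether an amine, a carboxylic acid or a longer chain in place of the methoxy, on the same aromatic carbon, would give a step beyond the scatter in this assay. Also open, going by these compounds, is whether the methoxy change would stay as small on a third core, and how much of the gap between the two cores comes from each place in which they differ.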